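Working notes: acetyl against isobutylcarbonyl in the series

The source may report more compounds than this note shows. Statements on the series, on what has been measured and on what is new or still open speak of the compounds shown alone.

Measured so far:
compound 1 `Cc1c(OCCCCOc2ccccc2C(=O)O)ccc(C(=O)CC(C)C)c1O`: 415 nM
compound 2 `Cc1c(OCCCCOc2ccc(C(=O)O)c(Cl)c2)ccc(C(=O)CC(C)C)c1O`: 151 nM
compound 3 `CC(=O)c1ccc(OCCCCOc2ccc(C(=O)O)cc2C)c(C)c1O`: 50 nM

All three were tested in an assay on HEK293 cells for positive allosteric modulation of metabotropic glutamate receptor 2 (Rattus norvegicus), read by thallium flux, with a stated time of 2.5 min; a lower number here means that less compound is needed, a higher number that more compound is needed for the effect. Among these numbers compound 3 stands lowest; compound 2 comes nearest, and compound 1 lies furthest away. Going by the values given here, the one step between compounds that differ in a single place is a 2.7-fold lower number from compound 1 to compound 2 (0.44 log units; beyond the scatter), a change on the acid-bearing ring rather than on the acyl group.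

Compound 4 `Cc1cc(C(=O)O)ccc1OCCCCOc1ccc(C(=O)CC(C)C)c(O)c1C` differs from compound 3 as follows: isopropyl in place of hydrogen on a saturated chain carbon bound to a carbonyl carbon. Among the compounds with values here, compounds 1 and 2 already carry the isobutylcarbonyl group, but each differs from compound 3 at the acid-bearing ring as well, so no measured step isolates this change; the gap between compound 2 and compound 3 mixes both differences. Within the data shown here, with no step bearing directly on the acyl group, the expectation for compound 4 in this assay is no step beyond the scatter, a 1.1-fold higher number from compound 3 to compound 4 (0.04 log units; within the scatter). Compound 4 is therefore estimated at 55 nM, with a range from 20 nM to 160 nM.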

Compound 4, half-maximal effective concentration: 192 nM
Estimate against measurement, compound 4: 3.5-fold (0.54 log units) below; measured number above the stated range.
By their numbers in this assay, from the lowest: compound 3; then compounds 2 and 4 (each within the scatter of the next); then compound 1.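

In this assay the acyl group now has a step of its own: isobutylcarbonyl in place of acetyl gives a 3.8-fold higher number from compound 3 to compound 4 (0.58 log units; beyond the scatter) with the acid-bearing ring unchanged, so this position does respond to the added isopropyl. With isobutylcarbonyl held fixed, the acid-bearing ring can also be read apart from the acyl group: 4-carboxy-2-methylphenyl in place of 4-carboxy-3-chlorophenyl gives a 1.3-fold higher number from compound 2 to compound 4 (0.10 log units; within the scatter) and so no separation, while the same ring in place of 2-carboxyphenyl gives a 2.2-fold lower number from compound 1 to compound 4 (0.33 log units; beyond the scatter) as a modest step. No evidence on the cause of these steps is at hand.

Open, going by these compounds, is where propionyl or cyclopropylcarbonyl would fall at this position. Also open, on these data alone, is whether the acyl step carries over to the 4-carboxy-3-chlorophenyl and 2-carboxyphenyl compounds, which appear here only with isobutylcarbonyl.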